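The compounds below may be only part of what the source reports. "The series", "measured", "known", "first", "only" and "open" are said of these compounds alone.

Of the compounds shown here, three have been measured in an assay for inhibition of protein deacetylase HDAC6 (Homo sapiens); on this read-out higher numbers stand for weaker inhibition and lower numbers for stronger inhibition. Compound 1 `NS(=O)(=O)NCCCC[C@H](NC(=O)OCc1ccccc1)C(=O)Nc1nccs1` gives 4100 nM, compound 2 `CCOC(=O)c1csc(NC(=O)[C@H](CCCCNS(N)(=O)=O)NC(=O)OCc2ccccc2)n1` gives 580 nM, and compound 3 `N[C@@H](CCCCNS(N)(=O)=O)C(=O)Nc1nc(-c2ccccc2)cs1` gives 1100 nM. Compound 3 therefore stands second highest of the three numbers: against compound 2 it lies within the scatter, while against compound 1 its number is clearly lower.

Compound 4 `CCOC(=O)N[C@@H](CCCCNS(N)(=O)=O)C(=O)Nc1nc(-c2ccccc2)cs1` differs from compound 3 in one place: ethoxycarbonyl in place of hydrogen on an amine nitrogen. Going by the values given here, no measured pair shows this same change at this position. Among the compounds with values here, the only step in which an ethoxycarbonyl group enters is a 7.1-fold lower number from compound 1 to compound 2 (0.85 log units; beyond the scatter), where the group was placed on an aromatic carbon rather than on the amine nitrogen, so it bears on the question only loosely. Compounds 1 and 2, which carry a larger carbamate on that same nitrogen, give numbers on both sides of compound 3, so the data do not settle the direction.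

On this basis the number for compound 4 is expected to move little, with a slight lowering at most, which is the step of a 1.4-fold lower number from compound 3 to compound 4 (0.14 log units; within the scatter). The estimate for compound 4 in this assay is 800 nM, with a likely range from 300 nM to 2500 nM.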

Compound 4, half-maximal inhibitory concentration: 200 nM
Estimate against measurement, compound 4: 4.0-fold (0.60 log units) above; measured number below the stated range.
By their numbers in this assay, from the lowest: compound 4; then compounds 2 and 3 (each within the scatter of the next); then compound 1.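

In this assay, going by these compounds alone, ethoxycarbonyl in place of hydrogen on this amine nitrogen gives a 5.5-fold lower number from compound 3 to compound 4 (0.74 log units; beyond the scatter), which is the first measured step at this position and lies beyond the scatter. On this core, then, the free amino group is not needed for a low number, and turning it into (ethoxycarbonyl)amino lowers the number instead of leaving it in place. Nothing available here explains why the number falls.

On these data alone, it remains open whether this gain needs ethoxycarbonyl itself or would also come with a smaller acetyl group or a simple methyl group on the same nitrogen. As far as these compounds go, it is also open whether the same change would lower the number on a core with a different group on the aromatic ring, such as the ethyl ester of compound 2.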